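The source may report more compounds than this note shows. Statements on the series, on what has been measured and on what is new or still open speak of the compounds shown alone.

Compound 1 `Cc1c(C(C)OC(=O)Nc2ccccc2)oc2ncnn12` gives 63.1 nM in a functional assay on CHO cells for antagonist activity at metabotropic glutamate receptor 5 (Homo sapiens), read by calcium flux (a higher number here means a weaker inhibitor, a lower number a stronger inhibitor), and stands lowest of the two numbers in hand. Among the measured compounds shown here, compound 2 `Cc1c(C(C)OC(=O)Nc2ccc(Cl)cc2)oc2ncnn12` gives 2510 nM in this assay; the one measured step, a 40-fold higher number from compound 1 to compound 2 (1.60 log units; beyond the scatter), is large but sits at a different aromatic carbon. Compound 3 `Cc1c(C(C)OC(=O)Nc2ccccc2)oc2nc(-c3cccs3)nn12` carries thiophen-2-yl in place of hydrogen on an aromatic carbon. For the measured compounds named here, no measured step touches this place, so that step offers only a weak guide. The expected step of a 1.6-fold higher number from compound 1 to compound 3 (0.20 log units; within the scatter) is therefore taken as small, with wide uncertainty. Compound 3 is expected to give about 100 nM in this assay, within 20 nM to 600 nM.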

Compound 3, half-maximal inhibitory concentration in the metabotropic glutamate receptor 5 assay: 7.94 nM
Compound 3: the middle estimate sits 13-fold (1.10 log units) above what was measured; the measured number lies below the stated range.
By their numbers in the metabotropic glutamate receptor 5 assay, from the lowest: compound 3; then compound 1; then compound 2.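

Among the compounds shown here, in the metabotropic glutamate receptor 5 assay, thiophen-2-yl on the aromatic carbon between two ring nitrogen atoms gives a 7.9-fold lower number from compound 1 to compound 3 (0.90 log units; beyond the scatter), so this position accepts a ring substituent with a gain, whereas the only earlier step, a 40-fold higher number from compound 1 to compound 2 (1.60 log units; beyond the scatter), went the other way at a different aromatic carbon. The gain comes with higher measured lipophilicity: the measured distribution coefficient of compound 1, 2.3, and of compound 3, 3.7, a number 1.40 log units higher (beyond the scatter) In a physicochemical assay for lipophilicity, at pH 7.4 (on this read-out lower numbers stand for lower lipophilicity and higher numbers for higher lipophilicity), compound 1 gives 2.3 and compound 3 gives 3.7.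

A single substituent here cannot separate any link to that lipophilicity from something particular to thiophen-2-yl. A phenyl ring or an amine such as morpholine on this carbon would bear on that question.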